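Swapping an Aryl Ether for a Pyrrolidine Ring

A few compounds are considered here, and "the series" means these few. Any claim that something is new, unique, unknown or untested is made for them only; others in the source may bear on it.

Of the compounds shown here, three sharing one core have been measured in a functional assay for inhibition of sodium/hydrogen exchanger (Oryctolagus cuniculus); a higher number here means a weaker inhibitor, a lower number a stronger inhibitor. Compound 1 `CCc1cc(C)c(C(=O)N=C(N)N)cc1S(C)(=O)=O` gives 4.8 nM. Compound 2 `Cc1cc(Sc2ccccc2)c(S(C)(=O)=O)cc1C(=O)N=C(N)N` gives 14 nM, and compound 3 `Cc1cc(Oc2ccc(Cl)cc2)c(S(C)(=O)=O)cc1C(=O)N=C(N)N` gives 13 nM. Compound 3 thus holds the second highest of the three numbers; its nearest neighbour is compound 2, and the two lie within the scatter of each other, so no order between them can be read. The step of a 2.7-fold higher number from compound 1 to compound 3 (0.43 log units; beyond the scatter) and the step of a 2.9-fold higher number from compound 1 to compound 2 (0.46 log units; beyond the scatter) both show that replacing the ethyl group by a larger aromatic substituent at that carbon gave a modestly higher number, while a 1.1-fold lower number from compound 2 to compound 3 (0.03 log units; within the scatter) shows that exchanging one such aromatic substituent for another changed little.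

Compound 4 `Cc1cc(N2CCCC2)c(S(C)(=O)=O)cc1C(=O)N=C(N)N` differs from compound 3 in one place: pyrrolidin-1-yl in place of 4-chlorophenoxy on an aromatic carbon. Going by the values given here, no measured compound carries a pyrrolidin-1-yl group here, so the only guide is that a small substituent at this carbon, ethyl in compound 1, gave the lowest number. Pyrrolidin-1-yl is smaller than 4-chlorophenoxy, and a return toward that number is expected, though the scatter could swallow it. The expected step of a 1.6-fold lower number from compound 3 to compound 4 (0.21 log units; within the scatter) is therefore a modest move to a lower number. Compound 4 is estimated at 8 nM, with a range from 3 nM to 25 nM.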

Compound 4, half-maximal inhibitory concentration: 11 nM
Compound 4: middle estimate off by 1.4-fold (0.14 log units), on the low side; the range from low to high includes it.
By their numbers in this assay, from the lowest: compound 1; then compounds 4, 3 and 2 (each within the scatter of the next).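

In this assay, pyrrolidin-1-yl cannot be told apart from either aromatic group at this carbon (a 1.2-fold lower number from compound 3 to compound 4 (0.07 log units; within the scatter); a 1.3-fold lower number from compound 2 to compound 4 (0.10 log units; within the scatter)), so a non-aromatic ring containing nitrogen sits in the same narrow band as 4-chlorophenoxy and phenylsulfanyl. Going from 8 heavy atoms in 4-chlorophenoxy to 5 heavy atoms in pyrrolidin-1-yl also does not restore the number seen with ethyl, and the modest gap to the ethyl compound remains (a 2.3-fold higher number from compound 1 to compound 4 (0.36 log units; beyond the scatter)), leaving compound 1 alone with the lowest number of the four. No measurement at hand explains why these three different groups land so close together.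

The compounds shown leave open whether a ring is needed at all here, a question that an open-chain dimethylamino group could address, and whether a larger piperidine ring would stay in the same band. They also leave open whether the low number of compound 1 is special to ethyl, which a methyl group, a propyl chain or a methoxy group at this carbon could test.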